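Chloro for methyl in a piperidinyl thiocarbonyl series

A few compounds are considered here, and "the series" means these few. Any claim that something is new, unique, unknown or untested is made for them only; others in the source may bear on it.

Compound 1 `Cc1ccc2c(=O)c(CSC(=S)N3CCCCC3)coc2c1` was tested in a functional assay on HeLa cells (Homo sapiens) for antiproliferative activity, read by MTT assay, with a stated time of 72 h; on this read-out lower numbers stand for stronger inhibition and higher numbers for weaker inhibition. In this assay compound 1 gives only a limit, > 25000 nM. Two measured neighbours show what the numbers in this series look like. Compound 3 `Cc1ccc2c(=O)c(CSC(=S)N3CCCC3)coc2c1`, which carries pyrrolidin-1-yl in place of piperidin-1-yl on the thiocarbonyl carbon, gives 4400 nM in this assay, so an at least 5.6-fold lower number from compound 1 to compound 3 (0.75 log units; beyond the scatter). Compound 2 `O=c1cc(CSC(=S)N2CCCC2)oc2cc(Cl)ccc12` carries the same pyrrolidin-1-yl together with a chloro group, and in this assay compound 2 gives again only a limit, > 40000 nM. Compound 4 `O=c1c(CSC(=S)N2CCCCC2)coc2cc(Cl)ccc12` is compound 1 with one change: chloro in place of methyl on an aromatic carbon. No measured step covers this exact change; the only step shown, from compound 1 to compound 3, concerns a different place. The values of compound 2 and compound 3 show that with pyrrolidin-1-yl the chloro compound sits at a limit while the methyl compound gives a number. For compound 4 the expected step is therefore a step that the limit leaves unreadable from compound 1 to compound 4, nothing beyond the scatter, because compound 2 in the matching pyrrolidin-1-yl pair gives > 40000 nM. Compound 4 is estimated at 40000 nM, within 15000 nM to 100000 nM, and will most likely be reported again as a limit.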

Compound 4, half-maximal inhibitory concentration: 440 nM
Estimate against measurement, compound 4: 91-fold (1.96 log units) above; the measured number lies below the stated range.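

In this assay, chloro in place of methyl on this aromatic carbon, meta to a fused ring and para to a fused ring, gives an at least 56-fold lower number from compound 1 to compound 4 (1.75 log units; beyond the scatter), a large change from exchanging a single heavy atom. For the compounds shown here, the earlier measured step concerned only the group on the thiocarbonyl carbon, and compound 2 differs from compound 4 in more than one place, so this is the first direct sign that the aromatic carbon also matters. The true size of the step cannot be read, only its lower bound, because compound 1 sits at a limit: the limit of > 25000 nM in this assay, at which 1 of the 4 values shown sits.

From the compounds shown here alone, what a bromo or a methoxy group would do on the same aromatic carbon remains open. Also open, going by these compounds, is whether chloro in place of methyl gives a similar step when pyrrolidin-1-yl replaces piperidin-1-yl on the thiocarbonyl carbon.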